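The source may report more compounds than this note shows. Statements on the series, on what has been measured and on what is new or still open speak of the compounds shown alone.

Compound 1 `Cn1c(-c2ccccc2)cnc1NC(=O)c1ncc[nH]1` is the parent of the small set; its core carries a phenyl on one aromatic carbon and an amide whose carbonyl bears 1H-imidazol-2-yl. In a toxicity assay on THP-1 cells (Homo sapiens) for inhibition (on this read-out higher numbers stand for lower toxicity in this test and lower numbers for higher toxicity in this test), compound 1 reaches only a limit, > 100000 nM. Compound 2 `Cn1c(-c2ccc(Cl)cc2)cnc1NC(=O)c1ncc[nH]1` carries chloro in place of hydrogen on an aromatic carbon and in this assay compound 2 gives 52000 nM. Compound 3 `Cn1c(-c2ccccc2Cl)cnc1NC(=O)c1ncc[nH]1` also carries chloro in place of hydrogen on an aromatic carbon; in this assay compound 3 reaches only a limit, > 50000 nM. The steps of an at least 1.9-fold lower number from compound 1 to compound 2 (0.28 log units; that floor lies within the scatter), a step that the two limits leave unreadable from compound 1 to compound 3 and a step that the limit leaves unreadable from compound 2 to compound 3 all concern the phenyl and leave the amide untouched, so none of them bears on the change to compound 4 `Cn1c(-c2ccccc2)cnc1NC(=O)c1cccc(Br)c1`: 3-bromophenyl in place of 1H-imidazol-2-yl on a carbonyl carbon. Going by the values given here, the three measured compounds sit at or near the limits the limit of > 100000 nM in this assay, at which 1 of the 3 values shown sits, and (the limit of > 50000 nM in this assay, at which 1 of the 3 values shown sits), and compound 2 is the only one with a number. Among the compounds with values here, for compound 4 the expected step is an at least 1.2-fold lower number from compound 1 to compound 4 (0.09 log units; that floor lies within the scatter), a change within the scatter, with no measured step to move the expectation. Compound 4 is therefore estimated at 80000 nM, between 30000 nM and 200000 nM, and a further limit rather than a number is quite likely.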

Compound 4, half-maximal cytotoxic concentration: > 50000 nM
Compound 4 ended at the assay's limit (the forecaster's own chance of this, stated with the estimate: 55%); the middle value does not contradict the limit.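

Compound 1 and compound 4 both end at limits in this assay, so the step between them cannot be read. The compounds shown leave open whether 3-bromophenyl in place of 1H-imidazol-2-yl on a carbonyl carbon changes the read-out at all.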